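A few compounds are considered here, and "the series" means these few. Any claim that something is new, unique, unknown or untested is made for them only; others in the source may bear on it.

In an ADME assay on HEK-293T cells (Homo sapiens) for cytotoxicity, read by luminescence, with a stated time of 24 h (a higher number here means that more compound is tolerated, a lower number that less compound is tolerated), compound 1 (`CCOC(=O)c1cc2sccc2n1Cc1ccc(OC)cc1`) gives > 100000 nM, which is a limit and not a number. Compound 2 (`COc1ccc(Cn2c(C(N)=O)cc3sccc32)cc1`) gives > 100000 nM, also a limit. Compound 3 (`CCCNC(=O)C1CCN(C(=O)c2cc3sc(C(C)=O)cc3n2Cc2ccc(OC)cc2)CC1`) gives > 100000 nM, again a limit. The three compounds thus stand together: the limit of > 100000 nM in this assay, at which 3 of the 3 values shown sit. Compound 4 (`CCCNC(=O)C1CCN(C(=O)c2cc3sc(CO)cc3n2Cc2ccc(OC)cc2)CC1`) carries hydroxymethyl in place of acetyl on an aromatic carbon, next to the ring sulfur: hydroxymethyl in place of acetyl on an aromatic carbon. Among the compounds with values here, the only measured step, a step that the two limits leave unreadable from compound 1 to compound 2, concerns a carbonyl carbon and offers no size to carry over. In this assay, the expected step, a number no higher from compound 3 to compound 4 (the limit leaves the size open), is therefore none beyond the scatter, in neither direction. Compound 4 is estimated at 100000 nM, with an expected range of 50000 nM to 200000 nM.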

Compound 4, half-maximal cytotoxic concentration: 15500 nM
Beside the measured number, compound 4's estimate is 6.5-fold (0.81 log units) above it; measured number below the stated range.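

In this assay, hydroxymethyl in place of acetyl on an aromatic carbon, next to the ring sulfur, gives an at least 6.4-fold lower number from compound 3 to compound 4 (0.80 log units; beyond the scatter). Compound 3 stands at a limit, so the step has a lower bound but no full size. Unlike the earlier compounds, compound 4 shows that one exchange at this position can bring a measurable number into a set otherwise held at a limit: the limit of > 100000 nM in this assay, at which 3 of the 4 values shown sit.

The compounds shown leave open whether the lower number goes with the hydrogen-bond donor that enters or with the acetyl that leaves. On these data alone, how an amine, a carboxylic acid or a longer chain would read at this place also stays open.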